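The source may hold more compounds than are shown below. What is called first, only, known or untested is meant among the compounds shown, and "the series" means these compounds.

Compound 2 `CC1(C)CC(O)(COc2ccc([C@H]3CC[C@]4(CC3)OOC3(O4)C4CC5CC(C4)CC3C5)cc2)CC(C)(C)N1` was tested in an ADME assay on the whole organism (strain FVB) for pharmacokinetics, with Mus musculus as the target, read by LC-MS, at a dose of 30 mg/kg by the oral route (a lower number here means less compound in the circulation, a higher number more compound in the circulation at the dose given), and gave 1000 nM. Its only comparator, compound 1 `c1cc([C@H]2CC[C@]3(CC2)OOC2(O3)C3CC4CC(C3)CC2C4)ccc1OC1CCNCC1`, gave 810 nM in the same assay, so compound 2 stands with the higher of the two numbers, yet the step of a 1.2-fold higher number from compound 1 to compound 2 (0.09 log units; within the scatter) is within the scatter, and the two values cannot be told apart. Compound 3 `c1cc([C@H]2CC[C@]3(CC2)OOC2(O3)C3CC4CC(C3)CC2C4)ccc1OCCOC1CCNCC1` is not yet measured. It differs from compound 2 at the group attached to the oxygen on the aromatic ring: ((piperidin-4-yl)oxy)methyl in place of 4-hydroxy-2,2,6,6-tetramethylpiperidin-4-yl on a saturated chain carbon bound to an oxygen on an aromatic ring. Among the compounds with values here, the one step that bears on this place, a 1.2-fold higher number from compound 1 to compound 2 (0.09 log units; within the scatter), shows that swapping the group on that oxygen left the maximal plasma concentration essentially unchanged, so no step beyond the scatter is expected here, in either direction. On that basis compound 3 is estimated at 900 nM, with a range from 400 nM to 2000 nM, meaning an expected step of a 1.1-fold lower number from compound 2 to compound 3 (0.05 log units; within the scatter).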

Compound 3, maximal plasma concentration: 633 nM
Compound 3: the middle estimate sits 1.4-fold (0.15 log units) above what was measured, within the range that was stated.
By their numbers in this assay, from the lowest: compounds 3, 1 and 2 (each within the scatter of the next).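

In this assay, the group on the oxygen on the aromatic ring can take a longer form without a step beyond the scatter: 2-((piperidin-4-yl)oxy)ethyl in place of piperidin-4-yl gives a 1.3-fold lower number from compound 1 to compound 3 (0.11 log units; within the scatter) and, cut one bond further out, ((piperidin-4-yl)oxy)methyl in place of 4-hydroxy-2,2,6,6-tetramethylpiperidin-4-yl gives a 1.6-fold lower number from compound 2 to compound 3 (0.20 log units; within the scatter). Three differently built groups, each holding a six-membered non-aromatic ring with a nitrogen, now stand within the scatter of one another at this position, where before there were only two. Nothing at hand explains these numbers.

Still open, on these data alone, is whether a group without that ring, such as an open-chain amine or a chain ending in a carboxylic acid, would move the maximal plasma concentration beyond the scatter.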